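This account rests on a few compounds, and the source may have more. Where it says the series, first, only, none or still open, it means among the compounds named here.

Of the compounds shown here, three have been measured for how strongly they prefer an oily environment over water, and a fourth awaits. In a physicochemical assay for lipophilicity, read by HPLC, measured as chromatographic lipophilicity, at pH 7.4 (on this read-out lower numbers stand for lower lipophilicity and higher numbers for higher lipophilicity), compound 1 `CC[C@H]1OC(=O)[C@H](C)[C@@H](O[C@H]2C[C@@](C)(OC)[C@@H](O)[C@H](C)O2)[C@H](C)[C@@H](O[C@@H]2O[C@H](C)C[C@H](N(C)C)[C@H]2O)[C@](C)(O)C[C@@H](C)CN(CCCNC(C)=O)[C@H](C)[C@@H](O)[C@]1(C)O` gives 2.06. In this assay compound 2 `CCCCC(=O)NCCCN1C[C@H](C)C[C@@](C)(O)[C@H](O[C@@H]2O[C@H](C)C[C@H](N(C)C)[C@H]2O)[C@@H](C)[C@H](O[C@H]2C[C@@](C)(OC)[C@@H](O)[C@H](C)O2)[C@@H](C)C(=O)O[C@H](CC)[C@@](C)(O)[C@H](O)[C@H]1C` gives 2.72. Compound 3 `CCCCCCCC(=O)NCCCN(C)[C@H]1C[C@@H](C)O[C@@H](O[C@@H]2[C@@H](C)[C@H](O[C@H]3C[C@@](C)(OC)[C@@H](O)[C@H](C)O3)[C@@H](C)C(=O)O[C@H](CC)[C@@](C)(O)[C@H](O)[C@@H](C)N(C)C[C@H](C)C[C@@]2(C)O)[C@@H]1O` gives 3.74 in this assay, the highest of the three; the difference between the core of compound 3 and the core of compound 2 is not broken down here. The step of a number 0.66 log units lower from compound 2 to compound 1 (beyond the scatter) comes from hydrogen in place of propyl on a saturated chain carbon bound to a carbonyl carbon. Compound 4 `CCCCC(=O)NCCCN(C)[C@H]1C[C@@H](C)O[C@@H](O[C@@H]2[C@@H](C)[C@H](O[C@H]3C[C@@](C)(OC)[C@@H](O)[C@H](C)O3)[C@@H](C)C(=O)O[C@H](CC)[C@@](C)(O)[C@H](O)[C@@H](C)N(C)C[C@H](C)C[C@@]2(C)O)[C@@H]1O` has not yet been measured in this assay; it differs from compound 3 by hydrogen in place of propyl on a saturated chain carbon, four bonds along the chain from a carbonyl carbon. This is the same kind of change, but the place differs: in the first pair the carbon is bound to a carbonyl carbon, whereas here it sits four bonds along the chain from a carbonyl carbon. A step of about the same size is expected, a number 0.69 log units lower from compound 3 to compound 4 (beyond the scatter), because the earlier removal of the propyl gave a number 0.66 log units lower from compound 2 to compound 1 (beyond the scatter). Compound 4 is therefore estimated to give 3.05, with a likely range from 2.6 to 3.5.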

Compound 4, distribution coefficient: 3.08
The estimate for compound 4 lay 0.03 log units below the measured number; the measured number falls inside the stated range.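

Hydrogen in place of propyl gives a number 0.66 log units lower from compound 3 to compound 4 (beyond the scatter) in this assay on this core, and the same kind of change gave a number 0.66 log units lower from compound 2 to compound 1 (beyond the scatter) on the other core, so the two printed steps have the same size even though the place differs: here the carbon sits four bonds along the chain from a carbonyl carbon, there it is bound to a carbonyl carbon. This shows that the change carried from one core to the other in this pair of pairs, but with a single example on each core it does not make a rule for other cores or for other chains. Nothing measured here explains why the two steps match.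

On these data alone, what stays open is whether the step would hold for a longer chain on either core, or whether it would hold at all with a carboxylic acid at the chain end. As far as these compounds go, whether other read-outs follow the same step also stays open.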